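Chloro on the benzoyl ring of an aminothiophene series

The compounds below may be only part of what the source reports. "The series", "measured", "known", "first", "only" and "open" are said of these compounds alone.

Measured compounds, with their read-outs in a functional assay on CHO cells for agonist activity at adenosine receptor A1 (Homo sapiens), read by fluorescence and ERK phosphorylation, with stated times of 30 min and 1.5 h, tested at 3 uM; a higher number here means a stronger effect of the compound at the concentration tested, a lower number a weaker effect:
compound 1, `Nc1scc(-c2cccc(Br)c2)c1C(=O)c1ccccc1`, gives 67%
compound 2, `Nc1scc(-c2ccc3ccccc3c2)c1C(=O)c1ccccc1`, gives 55%
compound 3, `Nc1scc(-c2cccc(Br)c2)c1C(=O)c1ccc(Cl)cc1`, gives 62%

Compound 1 and compound 3 share the same core and differ in one place: chloro in place of hydrogen on an aromatic carbon. The step that this change made in this assay is a number 5 percentage points lower from compound 1 to compound 3 (within the scatter), so within this pair the chloro has not moved the read-out in any way that can be told from repeat scatter.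

Compound 2 carries a different core from compound 1; the difference between the two cores is not broken down here. What the two values show is that compound 1 stands higher than compound 2 by a margin beyond the scatter, while compound 2 and compound 3 lie within the scatter of each other.

Compound 4, `Nc1scc(-c2ccc3ccccc3c2)c1C(=O)c1ccc(Cl)cc1`, has not yet been measured. It stands to compound 2 as compound 3 stands to compound 1: chloro in place of hydrogen on an aromatic carbon. The place of the change is the same in both pairs, so this is the same change made on the other core.

Within the data shown here, the step expected from compound 2 to compound 4 in this assay is a number 5 percentage points lower from compound 2 to compound 4 (within the scatter), resting on the single measured instance of the change, the step of a number 5 percentage points lower from compound 1 to compound 3 (within the scatter); the range is given added width since that step was seen on only one core. Compound 4 is therefore estimated at 50%, with a likely range from 37% to 63%.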

Compound 4, a percentage reported as activity, at one concentration (the size of the read-out at that concentration, not a potency): 54%
The estimate for compound 4 lay 4 percentage points below the measured number; the range from low to high includes it.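

In this assay, the step for phenyl to 4-chlorophenyl on the core of compound 2 is a number 1 percentage points lower from compound 2 to compound 4 (within the scatter), and set beside the step on the core of compound 1 it gives no sign that the two cores treat the change differently: the same change on two cores in this assay, a number 5 percentage points lower (within the scatter) from compound 1 to compound 3 and a number 1 percentage points lower (within the scatter) from compound 2 to compound 4, 4 percentage points apart, within the scatter of two such steps

Across these two pairs, then, the chloro carries from one core to the other without a shift in the read-out that can be told from repeat scatter, and the earlier step served as a fair guide to the new one. This does not show that the chloro is without effect in general or that the agreement extends beyond these two cores, since it rests on two pairs, both with steps within the scatter, and on a read-out taken at a single concentration, which gives the size of the effect and not a potency.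

Going by these compounds, whether a methoxy, a trifluoromethyl, an amine or a carboxylic acid in the place of the chloro would give a step beyond the scatter remains open. Also open, on these data alone, is whether any such step would carry between the two cores as closely as the chloro step does, and whether the same holds at other concentrations.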